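The source may report more compounds than this note shows. Statements on the series, on what has been measured and on what is new or still open speak of the compounds shown alone.

Compound 1 `CCC(=O)NCCCO[C@H]1[C@H](C)O[C@@H](O[C@H]2[C@H](C)[C@@H](O[C@@H]3O[C@H](C)C[C@H](N(C)C)[C@H]3O)[C@](C)(O)C[C@@H](C)CN(C)[C@H](C)[C@@H](O)[C@](C)(O)[C@@H](CC)OC(=O)[C@@H]2C)C[C@@]1(C)OC` is the more polar of the two macrolides measured so far: in a physicochemical assay for lipophilicity, read by HPLC, measured as chromatographic lipophilicity, at pH 7.4 (a lower number here means a more polar compound, a higher number a more lipophilic compound), compound 1 gives 2.54, whereas compound 2 `CC[C@H]1OC(=O)[C@H](C)[C@@H](O[C@H]2C[C@@](C)(OC)[C@@H](O)[C@H](C)O2)[C@H](C)[C@@H](O[C@@H]2O[C@H](C)C[C@H](N(C)C)[C@H]2O)[C@](C)(O)C[C@@H](C)CN(C)[C@H](C)[C@@H](OCCCNC(=O)c2c(C)nn(C)c2Cl)[C@]1(C)O` gives in this assay the value 3.01, a gap beyond the scatter. Compound 3 `CCCCCCCC(=O)NCCCO[C@H]1[C@H](C)O[C@@H](O[C@H]2[C@H](C)[C@@H](O[C@@H]3O[C@H](C)C[C@H](N(C)C)[C@H]3O)[C@](C)(O)C[C@@H](C)CN(C)[C@H](C)[C@@H](O)[C@](C)(O)[C@@H](CC)OC(=O)[C@@H]2C)C[C@@]1(C)OC` differs from compound 1 by pentyl in place of hydrogen on a saturated chain carbon, two bonds along the chain from a carbonyl carbon. For the measured compounds named here, no measured pair shows this change, but the five added chain carbons are expected to raise lipophilicity well beyond the scatter. For compound 3 the expected step of a number 1.86 log units higher from compound 1 to compound 3 (beyond the scatter) in this assay leads to an estimated value of 4.4, within the range 3.7 to 5.1.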

Compound 3, distribution coefficient: 4.1
For compound 3 the middle estimate is 0.30 log units above the measured one; the measured number falls inside the stated range.
By their numbers in this assay, from the lowest: compound 1; then compound 2; then compound 3.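

Pentyl in place of hydrogen on a saturated chain carbon, two bonds along the chain from a carbonyl carbon, gives a single-place step in this assay: a number 1.56 log units higher from compound 1 to compound 3 (beyond the scatter). The earlier compounds shown here could not show this, since compound 1 and compound 2 differ in more than one place. Nothing measured here explains the size of the step.

A single step leaves open whether the number rises evenly as the chain grows. On these data alone, how a shorter chain, a longer chain, an amine or a carboxylic acid in the same place would read also stays open.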